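The source may report more compounds than this note shows. Statements on the series, on what has been measured and on what is new or still open speak of the compounds shown alone.

In a functional assay on HeLa cells (Homo sapiens) for cytotoxicity, read by XTT assay, with a stated time of 72 h (on this read-out higher numbers stand for weaker inhibition and lower numbers for stronger inhibition), compound 3 `COc1ccc(Cc2cc(OC)c(OC)c(OC)c2)cc1O` gives 2.9 nM and belongs to the low end of the three numbers in hand. Compound 2 `COc1ccc(Cc2cc(OC)c(OC)c(OC)c2)cc1N` gives 3.2 nM and shares that low end within the scatter. Compound 1 `COc1ccc(Cc2ccc(OC)c(OC)c2OC)cc1N` gives 60 nM and stands clearly higher than both. Compound 4 `COc1ccc(Cc2cc(OC)c(OC)c(OC)c2)cc1[N+](=O)[O-]` is not yet measured in this assay and carries nitro in place of hydroxy on an aromatic carbon on the shared core. Within the data shown here, only one measured step touches this carbon: a 1.1-fold lower number from compound 2 to compound 3 (0.04 log units; within the scatter) for hydroxy in place of amino on an aromatic carbon, and it lies within the scatter. Among the measured compounds shown here, that step shows two groups reading alike, but the series holds no nitro compound, so the size of this change remains unmeasured. A modest move toward weaker inhibition is expected, with a real chance of no change beyond the scatter. The expected step is a 5.2-fold higher number from compound 3 to compound 4 (0.71 log units; beyond the scatter) on this estimate. Compound 4 is estimated at 15 nM with an expected range of 3 nM to 80 nM in this assay for now.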

Compound 4, half-maximal inhibitory concentration: 300 nM
Estimate against measurement, compound 4: 20-fold (1.30 log units) below; measured number outside the range, above it.
By their numbers in this assay, from the lowest: compounds 3 and 2 (each within the scatter of the next); then compound 1; then compound 4.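

In this assay this aromatic carbon does not tolerate every group, since hydroxy and amino read alike here but nitro brings a large rise in the number (a 100-fold higher number from compound 3 to compound 4 (2.01 log units; beyond the scatter)) and one of similar size from the amino side (a 94-fold higher number from compound 2 to compound 4 (1.97 log units; beyond the scatter)). The change from hydroxy to nitro goes from 1 hydrogen-bond donor to 0 hydrogen-bond donors and from 1 heavy atom to 3 heavy atoms, and the series does not separate these differences. Nothing at hand accounts for the size of the step.

The compounds shown leave open how a methyl, a fluorine or a carboxylic acid on this carbon would read, and so whether nitro is a lone exception. They also leave open whether nitro would produce a step of this size on the core of compound 1.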